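The source may report more compounds than this note shows. Statements on the series, on what has been measured and on what is new or still open speak of the compounds shown alone.

Measured in a functional assay on HCT-15 cells (Homo sapiens) for cytotoxicity, read by sulforhodamine B assay, with a stated time of 72 h; on this read-out higher numbers stand for weaker inhibition of growth and lower numbers for stronger inhibition of growth:
Compound 1 `O=C(Nc1ccccc1C(F)(F)F)C1CCc2ccccc2N1`: 40400 nM.
Compound 2 `CCC(=O)N1c2ccccc2CCC1C(=O)Nc1ccccc1C(F)(F)F`: > 80000 nM, which is a limit of the assay, not a number.

In this assay, for the measured compounds named here, compound 2 therefore stands only as a limit, and compound 1 gives the one real number in the set. Going by the values given here, the single measured step, an at least 1.9-fold higher number from compound 1 to compound 2 (0.29 log units; that floor lies within the scatter), is bounded by the limit of > 80000 nM in this assay, at which 1 of the 2 values shown sits, so its true size is unknown beyond that floor.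

The unmeasured compound 3 `O=C(Nc1ccccc1C(F)(F)F)C1CCc2ccccc2N1C(=O)c1cccc(Cl)c1` differs from compound 2 by 3-chlorophenyl in place of ethyl on a carbonyl carbon. Among the compounds with values here, no measured step concerns a change of this kind; the only step on record, an at least 1.9-fold higher number from compound 1 to compound 2 (0.29 log units; that floor lies within the scatter), concerns a different change, and it is itself only a floor. Nothing in the data points to a strong effect in either direction, and the starting point is a limit, so the expectation is wide and centred near weak growth inhibition.

Compound 3 is expected to give 60000 nM in this assay. The expected range for compound 3 runs from 15000 nM to 200000 nM. The step of an at least 1.3-fold lower number from compound 2 to compound 3 (0.12 log units; that floor lies within the scatter) is expected to lie within the scatter, with a real chance that compound 3 again returns only a limit.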

Compound 3, concentration for 50% growth inhibition: 797 nM
For compound 3 the middle estimate is 75-fold (1.88 log units) above the measured one; measured number below the stated range.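

On a carbonyl carbon whose other neighbour is the amide-type nitrogen in a ring, the choice of group matters greatly in this assay: 3-chlorophenyl in place of ethyl gives an at least 100-fold lower number from compound 2 to compound 3 (2.00 log units; beyond the scatter). As far as these compounds go, that step is only a floor, and its true size is unknown, as compound 2 stands at a limit of the assay and not at a real number: the limit of > 80000 nM in this assay, at which 1 of the 3 values shown sits. The comparison with the unsubstituted compound adds something the earlier step could not show, namely that a group on this nitrogen does not by itself weaken growth inhibition, for (3-chlorophenyl)carbonyl in place of hydrogen gives a 51-fold lower number from compound 1 to compound 3 (1.70 log units; beyond the scatter), so among these three compounds what is attached decides the outcome.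

The compounds shown leave open whether the gain belongs to the aromatic ring or to the chlorine on it, and an unsubstituted phenyl on the same carbonyl carbon would separate the two. They also leave open how a longer chain such as hexyl, or a group carrying an amine or a carboxylic acid, would fare at this place.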